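Toward an Amino Analogue of a Hydroxy Compound at the Limit

A few compounds are considered here, and "the series" means these few. Any claim that something is new, unique, unknown or untested is made for them only; others in the source may bear on it.

Of the compounds shown here, three have been tested in a toxicity assay on WI-38 cells (Homo sapiens) for cytotoxicity, read by MTT assay, with a stated time of 48 h; on this read-out lower numbers stand for stronger inhibition and higher numbers for weaker inhibition: compound 1 `O=C(/C=C/c1ccc2c(c1)B(O)OC2)c1cccnc1`, compound 2 `CSc1ccc(C(=O)/C=C/c2ccc3c(c2)B(O)OC3)cc1` and compound 3 `O=C(/C=C/c1ccc2c(c1)B(O)OC2)c1ccc(O)cc1`. In this assay compound 1 gives 76200 nM and compound 2 gives 54300 nM. Compound 3 reaches only a limit of the assay, > 100000 nM, which is the limit of > 100000 nM in this assay, at which 1 of the 3 values shown sits. Compound 4 `Nc1ccc(C(=O)/C=C/c2ccc3c(c2)B(O)OC3)cc1` differs from compound 3 by amino in place of hydroxy on an aromatic carbon. Among the measured compounds shown here, the measured steps that bear on this change are an at least 1.3-fold higher number from compound 1 to compound 3 (0.11 log units; that floor lies within the scatter) and an at least 1.8-fold higher number from compound 2 to compound 3 (0.26 log units; that floor lies within the scatter), both ending at that limit; none of the measured compounds carries an amino group. Compound 4 is therefore expected to remain close to the limit, with a number no higher from compound 3 to compound 4 (the limit leaves the size open) as the estimated step. The estimate for compound 4 is 100000 nM, within a range from 50000 nM to 200000 nM.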

Compound 4, half-maximal inhibitory concentration: 25400 nM
For compound 4 the middle estimate is 3.9-fold (0.60 log units) above the measured one, and the stated range ends above it.
By their numbers in this assay, from the lowest: compound 4; then compounds 2 and 1 (each within the scatter of the next). At a limit, above all of these: compound 3.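

In this assay, amino in place of hydroxy on this aromatic carbon, para to a large group, brings the number clear of the limit, with an at least 3.9-fold lower number from compound 3 to compound 4 (0.59 log units; beyond the scatter). The value of compound 3 is a limit, so that step is only a floor: the limit of > 100000 nM in this assay, at which 1 of the 4 values shown sits. Amino also stands apart from the other groups, with a 2.1-fold lower number from compound 2 to compound 4 (0.33 log units; beyond the scatter) and a 3.0-fold lower number from compound 1 to compound 4 (0.48 log units; beyond the scatter), whereas the earlier floors lay within the scatter. The compounds shown leave open whether a dimethylamino or an acetamido group on the same carbon would keep this lower number.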